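Swapping the sulfonyl aryl group of compound 3 for methylimidazolyl

A few compounds are considered here, and "the series" means these few. Any claim that something is new, unique, unknown or untested is made for them only; others in the source may bear on it.

Measured compounds:
compound 1 `O=C(CCCc1cn(S(=O)(=O)c2cccs2)c2ccccc12)NCCCn1ccnc1` with 5500 nM; 5010 nM (2 entries)
compound 2 `O=C(CCCc1cn(C(=O)c2cccs2)c2ccccc12)NCCCn1ccnc1` with 21400 nM
compound 3 `O=C(CCCc1cn(S(=O)(=O)c2ccc(F)cc2)c2ccccc12)NCCCn1ccnc1` with 6760 nM

Among the measured compounds shown here, in an assay on isolated protein for activation of Insulin-degrading enzyme (Homo sapiens), read by fluorescence, with stated times of 10 min and 20 min (a higher number here means that more compound is needed for the effect, a lower number that less compound is needed), compound 3 gives 6760 nM, the lowest of the single numbers, with compound 2 as its nearest neighbour in this assay at 21400 nM. Compound 1 carries two entries in this assay, 5500 nM; 5010 nM (2 entries), which stand within the scatter of compound 3, so no order between compound 1 and compound 3 can be read from them. For the measured compounds named here, the only measured step, a 3.2-fold lower number from compound 2 to compound 3 (0.50 log units; beyond the scatter), concerns the whole group on the aromatic nitrogen and not the aryl group on the sulfonyl sulfur. Compound 4 `Cn1cnc(S(=O)(=O)n2cc(CCCC(=O)NCCCn3ccnc3)c3ccccc32)c1` differs from compound 3 by 1-methyl-1H-imidazol-4-yl in place of 4-fluorophenyl on a sulfonyl sulfur. Going by the values given here, no measured step addresses an exchange of the aryl group on the sulfonyl alone; the comparison of compound 1 with compound 3 suggests that two different aryl groups there gave numbers within the scatter. Compound 4 is therefore expected to stay close to compound 3, with a step of a 1.2-fold higher number from compound 3 to compound 4 (0.07 log units; within the scatter) at most. The estimate for compound 4 is 8000 nM, with a range from 2500 nM to 25000 nM.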

Compound 4, half-maximal effective concentration: 28800 nM
Estimate against measurement, compound 4: 3.6-fold (0.56 log units) below, outside the stated range (above it).
By their numbers in this assay, from the lowest: compound 3; then compounds 2 and 4 (each within the scatter of the next).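

In this assay, among the compounds shown here, the group on the sulfonyl sulfur now makes a difference that the earlier compounds did not reveal: compound 1, with thiophen-2-yl, gives 5500 nM; 5010 nM (2 entries) and compound 3, with 4-fluorophenyl, gives 6760 nM, which lie within the scatter of each other, whereas 1-methyl-1H-imidazol-4-yl gives a 4.3-fold higher number from compound 3 to compound 4 (0.63 log units; beyond the scatter). The other new step, a 1.3-fold higher number from compound 2 to compound 4 (0.13 log units; within the scatter), shows that a sulfonyl on the aromatic nitrogen does not by itself secure the lower numbers of the two sulfonyl compounds with thiophen-2-yl and 4-fluorophenyl. The change is also wider than the spread of repeat entries in this series: the several entries of compound 1 in this assay, 5500 nM; 5010 nM (2 entries)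

On these data alone, whether a phenyl, a pyridinyl or a 1H-imidazol-4-yl without the methyl on the sulfonyl sulfur would stand nearer compound 3 or compound 4 remains open. As far as these compounds go, it is also open whether the step would hold with a carboxylic acid in place of the amide.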